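The compounds below may be only part of what the source reports. "The series", "measured", "known", "first", "only" and "open" are said of these compounds alone.

Measured compounds:
- compound 1 `COc1ccc(CN(C(=O)C2CC2)c2cc(OC)c(OC)c(OC)c2)cc1O`: 80 nM
- compound 2 `COc1ccc(CNc2cc(OC)c(OC)c(OC)c2)cc1Br`: 39800 nM

In a functional assay on KYSE-450 cells (Homo sapiens) for inhibition, read by MTT assay, with a stated time of 48 h (a lower number here means a stronger inhibitor, a higher number a weaker inhibitor), compound 1 gives 80 nM, the lowest of the two numbers recorded. Compound 2 gives 39800 nM, a far higher number, well beyond the usual scatter; the two structures differ in more than one place, so nothing is drawn from this pair about any single change.

Compound 3 `COc1ccc(CN(C(C)=O)c2cc(OC)c(OC)c(OC)c2)cc1O` has not yet been measured. It differs from compound 1 in one place: methyl in place of cyclopropyl on a carbonyl carbon. Among the compounds with values here, no step between measured compounds tells how this change plays out in this assay. The expectation is a small step, if any, towards a higher number, within or close to the scatter. Compound 3 is estimated at 150 nM, with a range of 50 nM to 500 nM, which means an expected step of a 1.9-fold higher number from compound 1 to compound 3 (0.27 log units; within the scatter).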

Compound 3, half-maximal inhibitory concentration: 160 nM
For compound 3 the middle estimate is 1.1-fold (0.03 log units) below the measured one; low and high end bracket the measured number.
By their numbers in this assay, from the lowest: compounds 1 and 3 (each within the scatter of the next); then compound 2.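

In this assay, methyl in place of cyclopropyl on a carbonyl carbon gives a 2.0-fold higher number from compound 1 to compound 3 (0.30 log units; within the scatter), so compound 1 and compound 3 cannot be told apart at this position. The three-membered ring is therefore not needed for a value in this range: compound 3, which carries only a methyl there, reads 160 nM. No measurement at hand offers an explanation for this result.

With only cyclopropyl and methyl shown on this carbonyl carbon, it remains open how far the position accepts other groups, such as a longer chain like n-butyl, a phenyl ring or a dimethylamino group. Whether a larger group here would leave the value within the scatter or shift it beyond the scatter also remains unanswered.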